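This account rests on a few compounds, and the source may have more. Where it says the series, first, only, none or still open, it means among the compounds named here.

Working notes on a small set of purine-derived amines carrying a methoxy-substituted benzyl group, tested in an ADME assay on BJ cells (Homo sapiens) for cytotoxicity, read by MTT assay, with a stated time of 72 h; on this read-out lower numbers stand for stronger inhibition and higher numbers for weaker inhibition.

Compound 1 `COc1ccccc1CNc1ncnc2c1ncn2C1CCCCO1` gives > 100000 nM in this assay, which is a limit of the assay and not a number. Compound 2 `COc1cccc(OC)c1CNc1ncnc2c1ncn2C1CCCCO1` likewise gives > 100000 nM in this assay, again a limit. Compound 3 `COc1cccc(CNc2ncnc3c2ncn3C2CCCO2)c1` gives > 100000 nM in this assay, also a limit. Going by the values given here, the one measured step, a step that the two limits leave unreadable from compound 1 to compound 2, corresponds to the change (methoxy in place of hydrogen on an aromatic carbon). The difference between the core of compound 1 and the core of compound 3 is not broken down here.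

Compound 4 `COc1cc(CNc2ncnc3c2ncn3C2CCCO2)cc(OC)c1` has not yet been measured in this assay. Its change from compound 3 is methoxy in place of hydrogen on an aromatic carbon, the same kind of change as from compound 1 to compound 2, though the surroundings differ: in compound 2 the new group sits ortho to a large group and meta to a methoxy group, whereas in compound 4 it sits meta to a large group and meta to a methoxy group.

For compound 4 the step expected in this assay is a number no higher from compound 3 to compound 4 (the limit leaves the size open), and this rests on compound 1 and compound 2 both sitting at the limit of > 100000 nM in this assay, at which 3 of the 3 values shown sit, across the same kind of change, so that no effect of the added methoxy is readable. Compound 4 is accordingly expected at 100000 nM, most likely reported again as a limit, with a range from 40000 nM to 300000 nM.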

Compound 4, half-maximal inhibitory concentration: > 100000 nM
Compound 4: no number, only a limit; the forecaster's own chance of this, stated with the estimate: 85%; the middle value sits exactly at the limit.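

No new step can be read from compound 3 to compound 4 in this assay. Both values are limits of the assay and not numbers, so the step cannot be sized: the limit of > 100000 nM in this assay, at which 4 of the 4 values shown sit.

The compounds shown leave open whether methoxy in place of hydrogen on an aromatic carbon has any effect in this assay, and how the four compounds compare with one another.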